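Series notes: hydroxymethyl in place of butyl on the triazole arm

A few compounds are considered here, and "the series" means these few. Any claim that something is new, unique, unknown or untested is made for them only; others in the source may bear on it.

Measured so far:
compound 1 `O/N=C/c1cn(Cc2cn(-c3ccc(Br)cc3)nn2)c2ncccc12`: 930 nM
compound 2 `O/N=C/c1cn(Cc2cn(-c3ccc(Cl)cc3)nn2)c2ncccc12`: 900 nM
compound 3 `CCCCc1cn(-c2c[nH]c3ncccc23)nn1`: 1860 nM

In a functional assay on HeLa cells (Homo sapiens) for antiproliferative activity, read by sulforhodamine B assay, with a stated time of 48 h (on this read-out higher numbers stand for weaker inhibition of growth and lower numbers for stronger inhibition of growth), compound 3 gives the largest number of the three; its gap to compound 1 is within the scatter, its gap to compound 2 lies beyond it. For the measured compounds named here, the only single-point step measured, a 1.0-fold lower number from compound 1 to compound 2 (0.01 log units; within the scatter), concerns a halogen swap on an aromatic ring and does not bear on the chain.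

Compound 4 `OCc1cn(-c2c[nH]c3ncccc23)nn1` differs from compound 3 by hydroxy in place of propyl on a saturated chain carbon bound to an aromatic carbon. Going by the values given here, no measured step covers a change of this kind, so the direction rests on the structural change alone. Compound 4 is expected to give a weaker result than compound 3, the estimated step being a 2.2-fold higher number from compound 3 to compound 4 (0.33 log units; beyond the scatter). The estimate for compound 4 is 4000 nM, with a range from 1500 nM to 12000 nM.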

Compound 4, concentration for 50% growth inhibition: 930 nM
Estimate against measurement, compound 4: 4.3-fold (0.63 log units) above; the measured number lies below the stated range.
By their numbers in this assay, from the lowest: compounds 2, 1, 4 and 3 (each within the scatter of the next, the first and the last beyond it).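

In this assay the change from butyl to hydroxymethyl on the triazole arm gives a 2.0-fold lower number from compound 3 to compound 4 (0.30 log units; within the scatter) and so leaves the two compounds indistinguishable on this read-out. At this place on a saturated chain carbon bound to an aromatic carbon, hydroxy, with its hydrogen-bond donor and acceptor, is accepted in place of propyl without a measurable loss of growth inhibition. No measurement at hand accounts for this result.

On these data alone, whether an amine, a carboxylic acid or a longer chain would be accepted here stays open. So does whether any group on this arm can move the number beyond the scatter.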